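The source may report more compounds than this note shows. Statements on the series, on what has been measured and on what is new or still open speak of the compounds shown alone.

Measured compounds: compound 1 `Cc1ccc(C2CNN=C2S(=O)(=O)CC2=NCCS2)cc1` gives 39.8%; compound 3 `Cc1ccc(C2CNN=C2S(=O)(=O)CC2=NCCO2)cc1` gives 41.3%; compound 2 `O=S(=O)(CC1=NCCS1)c1c(-c2ccccc2)noc1-c1ccccc1` is reported as "not active" (no number reported), with no number.

In a functional assay, tested at 50 ug/mL (a lower number here means a weaker effect, a higher number a stronger effect of the compound at the concentration tested), compound 1 and compound 3 differ by one change, (a group of 5 heavy atoms (3 carbon, 1 nitrogen, 1 oxygen; one five-membered non-aromatic ring with 2 hetero atoms) in place of a group of 5 heavy atoms (3 carbon, 1 nitrogen, 1 sulfur; one five-membered non-aromatic ring with 2 hetero atoms), on a saturated chain carbon bound to a sulfonyl sulfur), and the step of a number 1.5 percentage points higher from compound 1 to compound 3 (within the scatter) lies within the scatter, so the two values are not told apart. Compound 4 `O=S(=O)(CC1=NCCO1)c1c(-c2ccccc2)noc1-c1ccccc1` carries the same change on the core of compound 2, (a group of 5 heavy atoms (3 carbon, 1 nitrogen, 1 oxygen; one five-membered non-aromatic ring with 2 hetero atoms) in place of a group of 5 heavy atoms (3 carbon, 1 nitrogen, 1 sulfur; one five-membered non-aromatic ring with 2 hetero atoms), on a saturated chain carbon bound to a sulfonyl sulfur); the difference between the two cores is not broken down here. Since compound 2 is reported as not active with no number, and the same change on compound 1 gave a number 1.5 percentage points higher from compound 1 to compound 3 (within the scatter), the change is expected to leave compound 4 where compound 2 stands. Compound 4 is therefore estimated at 10% in this assay, between 0% and 30%, with a fair chance that only inactivity is reported.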

Compound 4, a percentage reported as activity, at one concentration (the size of the read-out at that concentration, not a potency): 57.2%
Estimate against measurement, compound 4: 47.2 percentage points below; measured number outside the range, above it.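

Going by these compounds alone, compound 2 is reported as not active with no number, so no step from it to compound 4 can be read in this assay. The compounds shown leave open how far the two cores differ in their response to this change, and no measurement given here bears on the result.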